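The source may report more compounds than this note shows. Statements on the series, on what has been measured and on what is new or still open speak of the compounds shown alone.

Compound 1 `Cc1nc(C(NC(=O)C(=O)Nc2ccc(C(F)(F)F)cc2)C2CCCCN2)sc1CO` in an ADME assay on TZM-b1 cells (Homo sapiens) for cytotoxicity, read by XTT assay, with a stated time of 3 days (on this read-out higher numbers stand for lower toxicity in this test and lower numbers for higher toxicity in this test), gives > 75500 nM, a limit of the assay. Compound 2 `CC(=O)c1ccc(NC(=O)C(=O)NC(c2nc(C)c(CCO)s2)C2CCCCN2)cc1` gives > 77300 nM, also a limit. Compound 3 `CC(=O)N1CCCCC1C(NC(=O)C(=O)Nc1ccc(Cl)cc1)c1nc(C)c(CCO)s1` gives > 84000 nM, again a limit.

Among the measured compounds shown here, compound 3 therefore stands at no number, only at the limit (the limit of > 84000 nM in this assay, at which 1 of the 3 values shown sits); the other two compounds sit likewise at limits, the limit of > 75500 nM in this assay, at which 1 of the 3 values shown sits, and (the limit of > 77300 nM in this assay, at which 1 of the 3 values shown sits), so no order among the three can be read and no measured step exists. Compound 4 `Cc1nc(C(NC(=O)C(=O)Nc2ccc(Cl)cc2)C2CCCN2)sc1CCO` differs from compound 3 by pyrrolidin-2-yl in place of 1-acetylpiperidin-2-yl on a saturated chain carbon bound to an amide-type nitrogen and an aromatic carbon. No step beyond the scatter is expected in this assay, in either direction, and a further limit is the likely outcome. Compound 4 is expected at about 85000 nM, between 40000 nM and 200000 nM. The expected step is a step that the limit leaves unreadable from compound 3 to compound 4, within the scatter.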

Compound 4, half-maximal cytotoxic concentration: 4900 nM
Beside the measured number, compound 4's estimate is 17-fold (1.24 log units) above it; measured number outside the range, below it.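

In this assay the group on this saturated chain carbon is not silent: pyrrolidin-2-yl in place of 1-acetylpiperidin-2-yl gives an at least 17-fold lower number from compound 3 to compound 4 (1.23 log units; beyond the scatter), and the lower number stands for higher toxicity in this test. Among the compounds shown here, compound 4 is the first of the series to give a number rather than a limit, so the size of the step is only a minimum. The compounds shown do not separate the change in ring size from the loss of the acetyl. A 1-acetylpyrrolidin-2-yl group at this place, with the rest of compound 4 kept, would tell the two apart.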